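The source may report more compounds than this note shows. Statements on the series, on what has been measured and on what is new or still open speak of the compounds shown alone.

Compound 1 `CSc1nnc(-c2cccc3ccccc23)n1C`: > 200 mg/kg (a limit)
Compound 2 `CSc1nc(-c2ccccc2)n(C)n1`: > 100 mg/kg (a limit)

Both compounds were tested in a functional assay on the whole organism for antagonist activity, with Mus musculus as the target, in the maximal electroshock model (on this read-out higher numbers stand for an effect only at larger amounts of compound and lower numbers for an effect already at smaller amounts), and neither gave a number. As far as these compounds go, for compound 2, the result is the limit > 100 mg/kg, so its true position on this read-out remains unknown.

Compound 3 `Cn1nc(S(C)(=O)=O)nc1-c1ccccc1` differs from compound 2 in one place: it has methylsulfonyl in place of methylsulfanyl on an aromatic carbon. Going by the values given here, no measured pair shows what this exchange does in this assay, so any expectation is tentative. The expected change is an at least 1.4-fold lower number from compound 2 to compound 3 (0.15 log units; that floor lies within the scatter), a modest estimated shift towards smaller amounts of compound. A result that is again only a limit would not be surprising. For compound 3 the estimated value is 70 mg/kg, with an expected range of 25 mg/kg to 200 mg/kg.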

Compound 3, dose for half-maximal effect: > 200 mg/kg
Compound 3: no number, only a limit (the forecaster's own chance of this, stated with the estimate: 45%); at least 2.8-fold (0.45 log units) between middle value and limit.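

In this assay compound 2 gives only the limit > 100 mg/kg. Compound 3 also gives only a limit, > 200 mg/kg. These two limits leave no readable step between compound 2 and compound 3. As far as these compounds go, it remains open where either compound truly stands, and whether methylsulfonyl in place of methylsulfanyl on an aromatic carbon changes the read-out at all.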